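Replacing pyridin-4-yl on a compound without a result

The source may hold more compounds than are shown below. What is called first, only, known or untested is meant among the compounds shown, and "the series" means these compounds.

Compound 2 (`CCC(c1ccc2ncccc2c1F)n1cnc2ncc(-c3ccncc3)nc21`) offers no number to start from: in a functional assay on NCI-H1993 cells (Homo sapiens) for inhibition, read by CCK-8 assay, with a stated time of 72 h (on this read-out higher numbers stand for weaker inhibition and lower numbers for stronger inhibition), compound 2 stands as "not determined" (no result reported) in the record. The nearest measured relative is compound 1 (`CC(c1c(F)cc2ncccc2c1F)n1cnc2ncc(-c3cnn(C)c3)nc21`), which gives 35.5 nM in this assay but differs from compound 2 in more than one place. Compound 3 (`CCC(c1ccc2ncccc2c1F)n1cnc2ncc(-c3ccc(C(N)=O)c(F)c3)nc21`) carries 4-carbamoyl-3-fluorophenyl in place of pyridin-4-yl on an aromatic carbon. Without a value for compound 2, the size of this change cannot be read directly, and no direction can be argued from it. The working expectation is a result no further than the usual scatter from compound 1 (35.5 nM), which is only a loose guide. Compound 3 is expected at about 30 nM in this assay, with an estimated range from 6 nM to 150 nM for this measurement.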

Compound 3, half-maximal inhibitory concentration: 665 nM
Beside the measured number, compound 3's estimate is 22-fold (1.35 log units) below it; the measured number lies above the stated range.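

Among these compounds, compound 2 has no number to set against compound 3, so no step between them can be read. No available evidence explains the result for compound 3. On these data alone, whether pyridin-4-yl or 4-carbamoyl-3-fluorophenyl gives stronger inhibition on the shared core remains open.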